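The source may report more compounds than this note shows. Statements on the series, on what has been measured and on what is new or still open speak of the compounds shown alone.

Compound 1 `CC1CCN(C2CCN(S(=O)(=O)c3ccccc3Br)CC2)CC1`: 3 nM
Compound 2 `Cc1cccc(S(=O)(=O)N2CCC(N3CCC(C)CC3)CC2)c1`: 25 nM
Compound 3 `CC1CCN(C2CCN(S(=O)(=O)c3ccc(-c4ccccc4)cc3)CC2)CC1`: 258 nM

These three share one core and differ only in the aryl group on the sulfonyl sulfur. In a functional assay on DLD-1 cells (Homo sapiens) for antiproliferative activity, read by CellTiter-Glo, with a stated time of 72 h (a lower number here means a stronger inhibitor, a higher number a weaker inhibitor), compound 3 gives 258 nM, the highest number of the three, while compound 2 gives 25 nM and compound 1 gives 3 nM. Compound 4 `CCc1ccc(S(=O)(=O)N2CCC(N3CCC(C)CC3)CC2)cc1` is not yet measured; its change from compound 3 is ethyl in place of phenyl on an aromatic carbon. Within the data shown here, the one measured step, an 8.3-fold higher number from compound 1 to compound 2 (0.92 log units; beyond the scatter), also exchanges the aryl group and was sizeable, but no measured pair exchanges a group at this place, so it bears only loosely here. Because compound 2 gives 25 nM with a single small substituent on the aryl ring, compound 4 is expected to move toward it, an expected step of a 4.3-fold lower number from compound 3 to compound 4 (0.63 log units; beyond the scatter). Compound 4 is thus estimated at 60 nM, between 15 nM and 250 nM.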

Compound 4, half-maximal inhibitory concentration: > 5000 nM
Compound 4: a limit, no number; the forecaster's own chance of this, stated with the estimate: 3%; at least 83-fold (1.92 log units) between middle value and limit.
By their numbers in this assay, from the lowest: compound 1; then compound 2; then compound 3. At a limit, above all of these: compound 4.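

Compound 4's value is a limit of the assay, not a number: the limit of > 5000 nM in this assay, at which 1 of the 4 values shown sits.

At this aromatic carbon, para to a large group, the smaller ethyl does worse than phenyl, with an at least 19-fold higher number from compound 3 to compound 4 (1.28 log units; beyond the scatter). Among these compounds, the aryl group therefore matters more than the earlier compounds showed, with an at least 200-fold higher number from compound 2 to compound 4 (2.30 log units; beyond the scatter) and an at least 1600-fold higher number from compound 1 to compound 4 (3.22 log units; beyond the scatter).

The compounds shown leave open whether this loss follows the ethyl group itself or its place on the ring. They also leave open whether a methoxy group, an amine or a carboxylic acid on this carbon would fare better.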